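This account rests on a few compounds, and the source may have more. Where it says the series, first, only, none or still open, it means among the compounds named here.

Compound 1, `CC1=C(C(=O)Nc2ccc(Br)cc2)C(c2ccc(Cl)cc2Cl)N=C(SCc2ccccc2)N1`, gives 3.6% in a functional assay on the whole organism (artery, strain albino) with Rattus norvegicus as the target, with a stated time of 30 min, at a dose of 10 mg/kg by the oral route; on this read-out higher numbers stand for more inhibition at the one dose given (going by the name of the read-out) and lower numbers for less inhibition.
Compound 2, `CC1=C(C(=O)Nc2ccc([N+](=O)[O-])cc2)C(c2ccc(Br)cc2)N=C(SCc2ccccc2Cl)N1`, gives 3.6% in this assay.
Compound 3, `CC1=C(C(=O)Nc2ccc([N+](=O)[O-])cc2)C(c2cccc([N+](=O)[O-])c2)N=C(SCc2ccccc2Cl)N1`, gives 3.6% in this assay.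

Compound 3 stands level with compound 1 and compound 2 at the digits shown; all three sit at the same low number, and the inhibition in this assay is level across them. Among the compounds with values here, the one step that joins two of them changed a group on a saturated ring carbon: no change at the digits printed from compound 2 to compound 3 (within the scatter). Compound 4, `CC1=C(C(=O)Nc2ccc([N+](=O)[O-])cc2)C(c2cccc([N+](=O)[O-])c2)N=C(SCc2ccc(F)cc2)N1`, differs from compound 3 in a different place, namely (4-fluorophenyl in place of 2-chlorophenyl on a saturated chain carbon bound to a sulfur). Within the data shown here, no measured pair bears directly on this change, and the change between compound 2 and compound 3 is the only guide to how this set responds to a swap of one aromatic ring for another; it lay within the scatter. Given that every value so far is equally low, a step within the scatter is expected: a number 0.4 percentage points higher from compound 3 to compound 4 (within the scatter). Compound 4 is therefore expected to give 4% in this assay, in a range from 0% to 15%.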

Compound 4, a percentage reported as inhibition, in the whole organism at one dose (the size of the read-out at that dose, not a potency): 4.1%
Beside the measured number, compound 4's estimate is 0.1 percentage points below it, within the range that was stated.
By their numbers in this assay, from the lowest: compounds 1, 2, 3 and 4 (each within the scatter of the next).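

Within the data shown here, replacing 2-chlorophenyl with 4-fluorophenyl on a saturated chain carbon bound to a sulfur gives a number 0.5 percentage points higher from compound 3 to compound 4 (within the scatter) in this assay and is the first single-place reading at this position. Both the halogen and its place on the ring differ here, yet the step stays within the scatter, as does no change at the digits printed from compound 2 to compound 3 (within the scatter) on a saturated ring carbon, so neither of the two positions tested singly has yet shifted the read-out beyond it. Nothing shown offers an explanation for this flat response.

On these data alone, all four compounds carry a phenyl ring on this chain carbon, so it remains open whether an amine, a carboxylic acid or a longer alkyl chain there would change the inhibition. Among these compounds, the carboxamide substituent also remains open, with no single-place step reading it.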